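Removing One Methoxy Group: Expected Effect on Cell Toxicity

The source may hold more compounds than are shown below. What is called first, only, known or untested is meant among the compounds shown, and "the series" means these compounds.

Measured so far in a functional assay on MDA-MB-468 cells (Homo sapiens) for inhibition, read by sulforhodamine B assay, with a stated time of 48 h; on this read-out lower numbers stand for higher toxicity in this test and higher numbers for lower toxicity in this test:
Compound 1, `COc1cc(-c2cc(/C=C/C(=O)c3ccc(N)cc3)[nH]n2)cc(OC)c1OC`, gives 8420 nM.
Compound 2, `COc1ccc(-c2cc(/C=C/C(=O)c3ccc(OC)c(OC)c3)[nH]n2)cc1`, gives 7120 nM.
Compound 3, `COc1cc(-c2cc(/C=C/C(=O)c3ccc(Cl)c(Cl)c3)[nH]n2)cc(OC)c1OC`, reached only a limit of the assay, > 100000 nM.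

Compound 1 and compound 2 lie within the usual scatter of each other, while compound 3 gave only a limit. For the measured compounds named here, the one measured step, an at least 11-fold higher number from compound 1 to compound 3 (1.07 log units; beyond the scatter), swaps the group on the carbonyl carbon; it is the single case where a value sits at the limit of > 100000 nM in this assay, at which 1 of the 3 values shown sits.

Compound 4, `COc1ccc(-c2cc(/C=C/C(=O)c3ccc(N)cc3)[nH]n2)cc1OC`, differs from compound 1 by hydrogen in place of methoxy on an aromatic carbon. Going by the values given here, no measured step touches this ring, so the step on the carbonyl side offers no direct guide, and a change within the scatter is expected: a 1.2-fold higher number from compound 1 to compound 4 (0.07 log units; within the scatter). Compound 4 is estimated at 10000 nM, between 3500 nM and 30000 nM.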

Compound 4, concentration lethal to 50% of the cells: 7800 nM
The estimate for compound 4 lay 1.3-fold (0.11 log units) above the measured number; the range from low to high includes it.
By their numbers in this assay, from the lowest: compounds 2, 4 and 1 (each within the scatter of the next). At a limit, above all of these: compound 3.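

In this assay, for the compounds shown here, hydrogen in place of methoxy on this aromatic carbon gives a 1.1-fold lower number from compound 1 to compound 4 (0.03 log units; within the scatter), and this is the first measured step on this ring. The earlier step changed only the carbonyl side, whereas this one shows that this methoxy group can be lost with no change this test can separate from scatter. Nothing measured here explains this result.

On these data alone, whether a hydroxyl group or a longer ether chain at this position would also stay within the scatter remains open. So does the effect of replacing either remaining methoxy group.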